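The source may report more compounds than this note shows. Statements on the series, on what has been measured and on what is new or still open speak of the compounds shown alone.

Compound 1, `CC(=O)Oc1ccc(/C=C/C(=O)OCCSc2nc(-c3ccc(S(C)(=O)=O)cc3)n(-c3ccc(F)cc3)n2)cc1OC(C)=O`: 11800 nM
Compound 2, `CC(=O)Oc1ccc(/C=C/C(=O)OCCSc2nc(-c3ccc(S(N)(=O)=O)cc3)n(-c3ccc(F)cc3)n2)cc1OC(C)=O`: 12000 nM

In a functional assay on A549 cells (Homo sapiens) for antiproliferative activity, read by MTT assay, with a stated time of 72 h (on this read-out higher numbers stand for weaker inhibition and lower numbers for stronger inhibition), compound 1 holds the lower of the two numbers, though the change a 1.0-fold higher number from compound 1 to compound 2 (0.01 log units; within the scatter) lies within the scatter, so neither compound can be called the stronger inhibitor. Compound 3, `COc1cc(/C=C/C(=O)OCCSc2nc(-c3ccc(S(C)(=O)=O)cc3)n(-c3ccc(F)cc3)n2)ccc1OC(C)=O`, differs from compound 1 by methyl in place of acetyl on an oxygen on an aromatic ring. Going by the values given here, the one measured step concerns the sulfonyl sulfur, not the oxygen on the aromatic ring, and so does not bear on this change; no comparable step is known. A step within the scatter is therefore expected, a 1.0-fold higher number from compound 1 to compound 3 (0.01 log units; within the scatter). For compound 3 in this assay the estimate is 12000 nM, between 5000 nM and 30000 nM.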

Compound 3, half-maximal inhibitory concentration: 9610 nM
The estimate for compound 3 lay 1.2-fold (0.10 log units) above the measured number, and the stated range covers the measured number.
By their numbers in this assay, from the lowest: compounds 3, 1 and 2 (each within the scatter of the next).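

On the oxygen on the aromatic ring, methoxy stands in compound 3 where acetoxy stands in compound 1, and in this assay this gives a 1.2-fold lower number from compound 1 to compound 3 (0.09 log units; within the scatter). The earlier pair concerned only the sulfonyl sulfur; this step shows that, at this oxygen too, the two groups cannot be told apart on this read-out. Going by these compounds, whether a free hydroxyl or a longer chain such as ethyl on this oxygen would also read alike remains open. Nothing measured here explains why acetyl and methyl read alike.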